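Replacing a Methylphenyl Group in a Cytotoxicity Series

A few compounds are considered here, and "the series" means these few. Any claim that something is new, unique, unknown or untested is made for them only; others in the source may bear on it.

Of the compounds shown here, two have so far been measured in an ADME assay on BJ cells (Homo sapiens) for cytotoxicity, with a stated time of 72 h; a lower number here means that less compound is needed, a higher number that more compound is needed for the effect.

compound 1, `CCc1ccc(-c2nc3c(c(C)nn3-c3ccccc3)c(-c3ccccc3I)c2C#N)cc1`: > 20000 nM
compound 2, `Cc1ccccc1-c1nc2c(c(C)nn2-c2ccccc2)c(-c2ccccc2O)c1C#N`: 21000 nM

Compound 1 shows > 20000 nM, which is a limit of the assay and not a number; it sits at the limit of > 20000 nM in this assay, at which 1 of the 2 values shown sits. Among the measured compounds shown here, compound 2 gives 21000 nM in this assay, the only number in this set, and it is a high one, meaning that much compound is needed for the effect.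

Compound 3, `Cc1nn(-c2ccccc2)c2nc(-c3ccc4c(c3)OCCO4)c(C#N)c(-c3ccccc3O)c12`, has not been measured. It differs from compound 2 in one place: 2,3-dihydro-1,4-benzodioxin-6-yl in place of 2-methylphenyl on an aromatic carbon. For the measured compounds named here, no step between two measured compounds is available to show how a change of this kind moves the read-out in this assay, and the two measured values give no direction either. The expected step is therefore none beyond the scatter: no change at the digits printed from compound 2 to compound 3 (within the scatter). Compound 3 is estimated at 21000 nM, with a range from 8000 nM to 50000 nM, and there is a fair chance that the assay again reports only a limit.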

Compound 3, half-maximal effective concentration: > 20000 nM
Compound 3 gave a limit, no number (the forecaster's own chance of this, stated with the estimate: 50%); the middle value does not contradict the limit.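

In this assay compound 3 gives > 20000 nM, which is a limit of the assay and not a number. Among the compounds shown here, no step from compound 2 to compound 3 can therefore be read, and compound 3 joins compound 1 at the same limit: the limit of > 20000 nM in this assay, at which 2 of the 3 values shown sit. From the compounds shown here alone, it remains open whether 2,3-dihydro-1,4-benzodioxin-6-yl in place of 2-methylphenyl moves the read-out at all.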